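Removing a trifluoromethyl from the weakest of three amides

A few compounds are considered here, and "the series" means these few. Any claim that something is new, unique, unknown or untested is made for them only; others in the source may bear on it.

Three compounds share one core and differ only in the group attached to the carbonyl carbon of an amide. In a functional assay on BGC-823 cells (Homo sapiens) for cytotoxicity, read by MTT assay, with a stated time of 72 h (a lower number here means a stronger inhibitor, a higher number a weaker inhibitor), compound 1 `CN1[C@@H]2c3[nH]c4ccccc4c3C[C@H]1[C@H](C#N)N1[C@@H](CNC(=O)c3ccc4ccccc4n3)c3[nH]c4ccccc4c3C[C@@H]21` gives 80 nM, compound 2 `CN1[C@@H]2c3[nH]c4ccccc4c3C[C@H]1[C@H](C#N)N1[C@@H](CNC(=O)c3cc4ccccc4s3)c3[nH]c4ccccc4c3C[C@@H]21` gives 240 nM, and compound 3 `CN1[C@@H]2c3[nH]c4ccccc4c3C[C@H]1[C@H](C#N)N1[C@@H](CNC(=O)/C=C/c3cccc(C(F)(F)F)c3)c3[nH]c4ccccc4c3C[C@@H]21` gives 910 nM. Compound 3 thus has the highest number of the three: the step of an 11-fold higher number from compound 1 to compound 3 (1.06 log units; beyond the scatter) and the step of a 3.8-fold higher number from compound 2 to compound 3 (0.58 log units; beyond the scatter) are both beyond the scatter.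

Compound 4 `CN1[C@@H]2c3[nH]c4ccccc4c3C[C@H]1[C@H](C#N)N1[C@@H](CNC(=O)/C=C/c3ccccc3)c3[nH]c4ccccc4c3C[C@@H]21` keeps the acyl group of compound 3 but with one change: hydrogen in place of trifluoromethyl on an aromatic carbon. Within the data shown here, none of the measured steps bears directly on this change; each of them (a 3.0-fold higher number from compound 1 to compound 2 (0.48 log units; beyond the scatter), an 11-fold higher number from compound 1 to compound 3 (1.06 log units; beyond the scatter), a 3.8-fold higher number from compound 2 to compound 3 (0.58 log units; beyond the scatter)) swaps the whole group on the carbonyl carbon, not a single substituent within it. Without a comparable step, the expectation for this assay is a number close to that of compound 3, with no step beyond the scatter expected in either direction. The step of a 1.0-fold lower number from compound 3 to compound 4 (0.00 log units; within the scatter) is therefore the estimate. For compound 4 the estimated value in this assay is 900 nM, expected to fall between 350 nM and 2300 nM.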

Compound 4, half-maximal inhibitory concentration: 4300 nM
Beside the measured number, compound 4's estimate is 4.8-fold (0.68 log units) below it; measured number outside the range, above it.
By their numbers in this assay, from the lowest: compound 1; then compound 2; then compound 3; then compound 4.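

In this assay, among these compounds, hydrogen in place of trifluoromethyl on the aromatic carbon gives a 4.7-fold higher number from compound 3 to compound 4 (0.67 log units; beyond the scatter) and so weakens the compound, which shows that one substituent within the acyl group can move the number beyond the scatter, whereas the earlier steps only swapped whole groups. Without the trifluoromethyl, the 2-phenylethenyl group falls further behind the other two acyl groups, with an 18-fold higher number from compound 2 to compound 4 (1.25 log units; beyond the scatter) against 1-benzothiophen-2-yl and a 54-fold higher number from compound 1 to compound 4 (1.73 log units; beyond the scatter) against quinolin-2-yl, making compound 4 the weakest of the four. Nothing measured here explains this effect.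

The compounds shown leave open whether trifluoromethyl is special at this place or whether a methyl, a chlorine or a methoxy would serve as well. They also leave open whether a trifluoromethyl on the quinolin-2-yl group of compound 1 would change the number.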